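From methoxymethyl to phenyl on a carbonyl carbon

This account rests on a few compounds, and the source may have more. Where it says the series, first, only, none or still open, it means among the compounds named here.

compound 1 `O=C(N[C@@H](CO)c1ccc(NC(=O)[C@H]2C[C@@H]2c2cccnc2)cc1)c1ccccc1` gives 200 nM
compound 2 `C[C@H](NC(=O)CC(F)(F)F)c1ccc(NC(=O)[C@H]2C[C@@H]2c2cccnc2)cc1` gives 5 nM
compound 3 `COCC(=O)N[C@@H](C)c1ccc(NC(=O)[C@H]2C[C@@H]2c2cccnc2)cc1` gives 30 nM

All three numbers come from a functional assay on A2780 cells (Homo sapiens) for antiproliferative activity, read by CellTiter-Glo, with a stated time of 4 days; on this read-out higher numbers stand for weaker inhibition and lower numbers for stronger inhibition. Compound 3 stands in the middle, with compound 2 lower and compound 1 higher. Compound 4 `C[C@H](NC(=O)c1ccccc1)c1ccc(NC(=O)[C@H]2C[C@@H]2c2cccnc2)cc1` differs from it in one group: phenyl in place of methoxymethyl on a carbonyl carbon. Among the compounds with values here, the only measured step at this end of the molecule is a 6.0-fold higher number from compound 2 to compound 3 (0.78 log units; beyond the scatter), which shows that changes here can register. Compound 1 also carries benzoyl and gives 200 nM, though the rest of it is not identical to compound 4. A modest step towards a higher number in this assay therefore seems likeliest, although a lower number cannot be excluded. The expected step is a 1.3-fold higher number from compound 3 to compound 4 (0.12 log units; within the scatter). For compound 4 the estimated value is 40 nM, with an expected range from 10 nM to 150 nM.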

Compound 4, half-maximal inhibitory concentration: 1 nM
The estimate for compound 4 lay 40-fold (1.60 log units) above the measured number, and the stated range ends above it.
By their numbers in this assay, from the lowest: compound 4; then compound 2; then compound 3; then compound 1.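

In this assay, the change from methoxymethyl to phenyl on this carbonyl carbon gives a 30-fold lower number from compound 3 to compound 4 (1.48 log units; beyond the scatter), so this position can respond far more strongly than the earlier step suggested. Phenyl also outperforms 2,2,2-trifluoroethyl here, with a 5.0-fold lower number from compound 2 to compound 4 (0.70 log units; beyond the scatter), so it gives the lowest number of the three groups compared on this carbonyl carbon. Benzoyl alone does not guarantee this result: hydrogen in place of hydroxy on the saturated chain carbon gives a 200-fold lower number from compound 1 to compound 4 (2.30 log units; beyond the scatter), a large step in the same assay.

As far as these compounds go, whether a chlorophenyl, a longer chain or an amine on this carbonyl carbon would keep the number as low remains open. No available evidence explains these steps.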